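The compounds below may be only part of what the source reports. "The series", "measured", "known", "first", "only" and "open" are said of these compounds alone.

Measured so far:
- compound 1 `Cc1c(O)c(C)c2c(c1O)C(=O)CC(c1cccc(O)c1)O2`: > 20000 nM
- compound 2 `COc1ccccc1C1CC(=O)c2c(O)c(C)c(O)c(C)c2O1`: > 20000 nM
- compound 3 `COc1ccc(C2CC(=O)c3c(O)c(C)c(O)c(C)c3O2)c(OC)c1`: "not active" (no number reported)

For the measured compounds named here, all work on this series so far comes from a functional assay on HUVEC cells (Homo sapiens); a lower number here means that less compound is needed, a higher number that more compound is needed for the effect. Compound 1 gives > 20000 nM, which is a limit of the assay and not a number. Compound 2 gives > 20000 nM, also a limit and not a number. Compound 3 is recorded as "not active" (no number reported). Compound 1 therefore stands with compound 2 at the limit of > 20000 nM in this assay, at which 2 of the 3 values shown sit, and none of the three compounds has a number yet.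

Next in line is compound 4 `Cc1c(O)c(C)c2c(c1O)C(=O)CC(c1ccco1)O2`, which has furan-2-yl in place of 3-hydroxyphenyl on a saturated ring carbon, next to the ring oxygen. The counted change is furan-2-yl in place of 3-hydroxyphenyl on a saturated ring carbon.

Going by the values given here, no measured step between two compounds is available to size this change. The expectation rests only on compound 1 and its limit of > 20000 nM. Expected in this assay: a number no higher from compound 1 to compound 4 (the limit leaves the size open), which means nothing beyond the scatter and no clear direction. A report of a limit alone is also expected to be more likely than a number. For compound 4 the estimate is 20000 nM, with an expected range from 6000 nM to 40000 nM.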

Compound 4, half-maximal effective concentration: > 20000 nM
Compound 4 gave a limit, no number (the forecaster's own chance of this, stated with the estimate: 65%); the middle value lies on the limit itself.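

In this assay compound 4 gives > 20000 nM, a limit of the assay and not a number, so no step can be read from compound 1 to compound 4. The series stays where it stood: the limit of > 20000 nM in this assay, at which 3 of the 4 values shown sit. The compounds shown leave open whether any change on the shared core yields a measurable number in this assay.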